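Pyrrolidine for morpholine on the thiosemicarbazide amidrazone series

The source may report more compounds than this note shows. Statements on the series, on what has been measured and on what is new or still open speak of the compounds shown alone.

Measured compounds, all in a functional assay on A-431 cells (Homo sapiens) for cytotoxicity, read by MTT assay, with a stated time of 72 h, tested at 100 uM; on this read-out lower numbers stand for less inhibition of growth and higher numbers for more inhibition of growth at the one concentration tested:
Compound 1, `N/C(=N\NC(=S)N1CCOCC1)c1ccccn1`: 84.6%
Compound 2, `Cc1ccnc(/C(N)=N/NC(=S)N2CCSCC2)c1`: 79.6%
Compound 3, `Cc1cccc(/C(N)=N/NC(=S)N2CCOCC2)n1`: 84.8%

Compound 3 gives the highest of the three numbers in this assay, but its gap to compound 1 and its gap to compound 2 are both within the usual scatter, so the three compounds are not separated on this read-out. Going by the values given here, the one step between measured compounds that differ in a single place, a number 0.2 percentage points higher from compound 1 to compound 3 (within the scatter), is also within the scatter.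

Compound 4, `Cc1cccc(/C(N)=N/NC(=S)N2CCCC2)n1`, differs from compound 3 by pyrrolidin-1-yl in place of morpholin-4-yl on a thiocarbonyl carbon. Among the compounds with values here, no measured step concerns this change; the nearest comparison is compound 2, whose thiomorpholine ring gives a number within the scatter of compound 3. The measured step from compound 1 to compound 3 bears only on the methyl and is uninformative here. With no step beyond the scatter anywhere in the set, compound 4 is expected to stay close to compound 3, with an estimated step of a number 4.8 percentage points lower from compound 3 to compound 4 (within the scatter). The estimate for compound 4 in this assay is 80%, with a range from 60% to 92%.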

Compound 4, percent growth inhibition at one concentration: 86.8%
Beside the measured number, compound 4's estimate is 6.8 percentage points below it, and the stated range covers the measured number.
By their numbers in this assay, from the lowest: compounds 2, 1, 3 and 4 (each within the scatter of the next).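

Exchanging morpholin-4-yl for pyrrolidin-1-yl on a thiocarbonyl carbon gives, in this assay, a number 2 percentage points higher from compound 3 to compound 4 (within the scatter). Going by these compounds alone, this is the only measured step at this place, and it shows that the six-membered ring with its oxygen can give way to the five-membered ring with no oxygen without separating the two compounds on this read-out. The measurements shown offer nothing that would explain this result.

The compounds shown leave open whether a piperazin-1-yl ring, a piperidin-1-yl ring or an open-chain dimethylamino group on the same thiocarbonyl carbon would separate from compound 3. They also leave open whether compound 3 and compound 4 would differ at any concentration other than the single one tested.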